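The source may report more compounds than this note shows. Statements on the series, on what has been measured and on what is new or still open speak of the compounds shown alone.

Compound 1 `CC(=O)N1N=C(Nc2nc3ccccc3s2)CC1OC1=CC=C1`: "not determined" (no result reported) in a functional assay on the whole organism (strain albino) with Mus musculus as the target, with a stated time of 0.5 h; a higher number here means that more compound is needed for the effect, a lower number that less compound is needed.
Compound 2 `CC(=O)N1N=C(Nc2nc3ccc(Cl)cc3s2)CC1OC1=CC=C1`: "not determined" (no result reported) in this assay.
Compound 3 `COc1ccc(C2CC(Nc3nc4ccc([N+](=O)[O-])cc4s3)=NN2C(C)=O)cc1`: 149 umol/kg in this assay.

Going by the values given here, compound 2 stands without a single number in this assay, and compound 1 stands the same way, so the only number here comes from compound 3. In this assay compound 3 gives 149 umol/kg. Compound 4 `COc1ccc(C2CC(Nc3nc4ccc(Cl)cc4s3)=NN2C(C)=O)cc1O` is not yet measured. It differs from compound 2 by a group of 9 heavy atoms (7 carbon, 2 oxygen; one six-membered aromatic ring of carbon only) in place of a group of 5 heavy atoms (4 carbon, 1 oxygen; one four-membered non-aromatic ring of carbon only), on a saturated ring carbon. No step between measured compounds is shown, and compound 2 has no number in this assay, so the size and direction of the move from compound 2 to compound 4 cannot be read from these data; nothing beyond the usual scatter can be expected on this evidence. Resting on compound 3 and its 149 umol/kg, compound 4 is expected to give about 150 umol/kg in this assay, within 50 umol/kg to 450 umol/kg.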

Compound 4, dose for half-maximal effect: 132 umol/kg
Compound 4: middle estimate off by 1.1-fold (0.06 log units), on the high side; measured number inside the range.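

In this assay, going by these compounds alone, compound 2 has no single number, so no step to compound 4 can be read. The effect of the 3-hydroxy-4-methoxyphenyl group on this core stays open, and no measured evidence offers an explanation.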